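Shifting a methyl on the phenyl ring of a hydroxamic acid

The compounds below may be only part of what the source reports. "The series", "measured", "known", "first", "only" and "open" are said of these compounds alone.

Compound 1 `O=C(CCC1=CCN(CCCc2ccc(Cl)cc2)C1=O)NO`: 3480 nM in a functional assay on PC-3 cells (Homo sapiens) for inhibition, read by sulforhodamine B assay; on this read-out lower numbers stand for stronger inhibition of growth and higher numbers for weaker inhibition of growth
Compound 2 `Cc1ccccc1CCCN1CC=C(CCC(=O)NO)C1=O`: 3480 nM in this assay

Compound 2 is level with compound 1 at the digits shown; its only measured neighbour is compound 1, and the step of no change at the digits printed from compound 1 to compound 2 (within the scatter) was flat within the scatter. Compound 3 `Cc1cccc(CCCN2CC=C(CCC(=O)NO)C2=O)c1` has not yet been measured in this assay. It differs from compound 2 as follows: 3-methylphenyl in place of 2-methylphenyl on a saturated chain carbon, three bonds along the chain from an amide-type nitrogen in a ring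

Going by the values given here, the one measured step that bears on this change is the swap of one aryl group for another at the same place on the chain, from compound 1 to compound 2, and it produced no movement beyond the scatter. Among the compounds with values here, with only that precedent, and with the atoms of compound 3 identical to those of compound 2 and only joined differently, the expectation is that moving the methyl around the ring leaves the growth inhibition where it is. The step expected from compound 2 to compound 3 in this assay is therefore a 1.0-fold higher number from compound 2 to compound 3 (0.00 log units; within the scatter), none beyond the scatter. Compound 3 is estimated at 3500 nM in this assay, within a range from 1700 nM to 7200 nM.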

Compound 3, concentration for 50% growth inhibition: 3480 nM
Beside the measured number, compound 3's estimate is 1.0-fold (0.00 log units) above it; measured number inside the range.
By their numbers in this assay, from the lowest: compounds 1, 2 and 3 (each within the scatter of the next).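

In this assay, the step of no change at the digits printed from compound 2 to compound 3 (within the scatter) shows that this read-out does not tell 3-methylphenyl from 2-methylphenyl at this place on the chain, so the placement of the methyl on the phenyl ring is now tested with the atoms held the same. The earlier pair had swapped both the group on the ring and its placement at once, and the further step no change at the digits printed from compound 1 to compound 3 (within the scatter) now sets 3-methylphenyl level with 4-chlorophenyl as well, so all three aryl groups shown lie within the scatter of one another. Nothing measured here accounts for this flat result.

The compounds shown leave open whether this flatness holds for groups of another kind on the phenyl ring, such as a methoxy group, an amine or a carboxylic acid, or for 4-methylphenyl, which would complete the series of methyl placements. They also leave open whether a shorter or longer chain between the ring nitrogen and the phenyl ring would part from the values seen so far.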